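This account rests on a few compounds, and the source may have more. Where it says the series, first, only, none or still open, it means among the compounds named here.

Measured so far:
compound 1 `O=C(O)c1cnc(-c2ccccc2F)[nH]c1=O`: 5 mg/kg
compound 2 `O=C(O)c1cnc(-c2ccccc2O)[nH]c1=O`: > 5 mg/kg, a limit of the assay

Among the measured compounds shown here, in a functional assay on the whole organism (strain Sprague-Dawley) for inhibition, with Rattus norvegicus as the target, with a stated time of 10 min (on this read-out lower numbers stand for an effect already at smaller amounts and higher numbers for an effect only at larger amounts of compound), compound 1 gives the only number in the set. For compound 2 the read-out is a limit, not a number. The step of a number no lower from compound 1 to compound 2 (the limit leaves the size open) is of unreadable size because compound 2 sits at the limit of > 5 mg/kg in this assay, at which 1 of the 2 values shown sits.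

Compound 3 `CC(C)Oc1ccccc1-c1ncc(C(=O)O)c(=O)[nH]1` is not yet measured. It differs from compound 1 by isopropoxy in place of fluoro on an aromatic carbon. For the measured compounds named here, only the step from compound 1 to compound 2 bears on this change, and its size is open, so no firm direction can be read. Compound 3 is therefore expected at 8 mg/kg, between 3 mg/kg and 25 mg/kg. That estimate means a step of a 1.6-fold higher number from compound 1 to compound 3 (0.20 log units; within the scatter).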

Compound 3, dose for 50% inhibition: 0.8 mg/kg
Compound 3: the middle estimate sits 10-fold (1.00 log units) above what was measured; measured number below the stated range.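

On this assay, the aromatic carbon ortho to a large group proves able to carry a group much larger than fluoro with a gain in effect: isopropoxy in place of fluoro gives a 6.3-fold lower number from compound 1 to compound 3 (0.80 log units; beyond the scatter). Isopropyl in place of hydrogen on the oxygen gives an at least 6.2-fold lower number from compound 2 to compound 3 (0.79 log units; beyond the scatter). That step stays open on one side because compound 2 stands at a limit of the assay: the limit of > 5 mg/kg in this assay, at which 1 of the 3 values shown sits.

Going by these compounds, whether a shorter methoxy or a longer butoxy chain would do as well at this place remains open, as does the effect of an amine there.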